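A few compounds are considered here, and "the series" means these few. Any claim that something is new, unique, unknown or untested is made for them only; others in the source may bear on it.

Compound 3, `CCOC(=O)C1=C(Nc2ccc(C(F)(F)F)cc2)S/C(=C\c2ccc[nH]2)C1=O`, stands highest of the two numbers shown in a functional assay on MCF7 cells (Homo sapiens) for inhibition, read by MTT assay, with a stated time of 72 h, tested at 10 uM (on this read-out higher numbers stand for more inhibition at the one concentration tested (going by the name of the read-out) and lower numbers for less inhibition), where compound 3 gives 19.1%. Its nearest neighbour is compound 1, `CCOC(=O)C1=C(Nc2ccccc2)S/C(=C\c2ccc[nH]2)C1=O`, which in this assay gives 18.3%; the change a number 0.8 percentage points higher from compound 1 to compound 3 (within the scatter) lies within the scatter. Compound 2, `CCOC(=O)C1=C(Nc2ccc(OC)cc2)S/C(=C\c2ccc[nH]2)C1=O`, reports only a limit in this assay, < 10%, and this is the limit of < 10% in this assay, at which 1 of the 3 values shown sits. From there the steps read a number at least 8.3 percentage points lower from compound 1 to compound 2 (that floor lies within the scatter) and a number at least 9.1 percentage points higher from compound 2 to compound 3 (that floor lies within the scatter), each with a floor that itself sits inside the scatter.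

Compound 4, `CCOC(=O)C1=C(Nc2ccc(C)cc2)S/C(=C\c2ccc[nH]2)C1=O`, differs from compound 3 by methyl in place of trifluoromethyl on an aromatic carbon. The measured steps that bear on this change are the two exchanges at the same aromatic carbon: the exchange of hydrogen for trifluoromethyl, a number 0.8 percentage points higher from compound 1 to compound 3 (within the scatter), moved the read-out by nothing beyond the scatter, while the exchange of hydrogen for methoxy, a number at least 8.3 percentage points lower from compound 1 to compound 2 (that floor lies within the scatter), took the value down to the limit. Methyl is neither of those groups, so no step beyond the scatter is firmly anticipated in this assay, though a modest slide toward the limit cannot be ruled out. Compound 4 is therefore expected to give about 15%, with a range from 5% to 25%. That estimate corresponds to an expected step of a number 4.1 percentage points lower from compound 3 to compound 4 (within the scatter).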

Compound 4, a percentage reported as inhibition, at one concentration (the size of the read-out at that concentration, not a potency): < 10%
Compound 4: no number, only a limit (the forecaster's own chance of this, stated with the estimate: 30%); at least 5 percentage points between middle value and limit.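

The step reads a number at least 9.1 percentage points lower from compound 3 to compound 4 (that floor lies within the scatter), and against the unsubstituted compound it reads a number at least 8.3 percentage points lower from compound 1 to compound 4 (that floor lies within the scatter), so in this assay both readable steps end at a limit and neither floor clears the scatter. Among the compounds shown here, until now methoxy was the only group at this place, on an aromatic carbon of a six-membered aromatic ring of carbon only, para to a large group, to give a limit; methyl now does the same, so the limit no longer belongs to compound 2 alone, while compound 1 and compound 3 go against any rule that a group at this place brings the limit. Compound 2 and compound 4 each report a limit and not a number, so the step between them cannot be read: the limit of < 10% in this assay, at which 2 of the 4 values shown sit.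

The compounds shown leave open how far compound 2 and compound 4 actually lie from each other, and whether any group at this place can raise the read-out beyond the scatter from compound 1. Going by these compounds, whether a chlorine atom, an amine or a carboxylic acid at the same carbon would give a number or a limit also stays open.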